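The source may hold more compounds than are shown below. What is called first, only, known or untested is meant among the compounds shown, and "the series" means these compounds.

Working notes on the series. Compound 1 `Cn1c(=O)c2nc(-c3ccc(Cl)cc3)[nH]c2n(C)c1=O` is the reference point; in an assay for binding affinity to adenosine receptor A1 (Bos taurus) (on this read-out higher numbers stand for weaker inhibition and lower numbers for stronger inhibition), compound 1 gives 0.8 nM. Among the three measured compounds it holds the second highest number. Compound 2 `Cn1c(=O)c2nc(-c3ccc(Cl)cc3N)[nH]c2n(C)c1=O` gives 0.35 nM, and the step of a 2.3-fold lower number from compound 1 to compound 2 (0.36 log units; beyond the scatter) comes from an amino in place of hydrogen on an aromatic carbon. Among the compounds with values here, compound 3 `Cn1c(=O)c2nc(-c3ccccc3O)[nH]c2n(C)c1=O` gives 10 nM, a number well above that of compound 1; no single-point step links these two, so only the two values are set side by side.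

Compound 4 `Cn1c(=O)c2nc(-c3ccc([N+](=O)[O-])cc3)[nH]c2n(C)c1=O` has not yet been measured. It differs from compound 1 by nitro in place of chloro on an aromatic carbon. Within the data shown here, no measured step covers a change of this kind: the one step that exists, a 2.3-fold lower number from compound 1 to compound 2 (0.36 log units; beyond the scatter), adds a group at a different place and keeps the chloro, so it does not speak to what a nitro in place of chloro does. The change is therefore read without a direct precedent, and a step anywhere from slightly lower to moderately higher in this assay is plausible, with the scatter alone able to account for much of it.

On that basis compound 4 is expected to show a 2.5-fold higher number from compound 1 to compound 4 (0.40 log units; beyond the scatter). The estimate for compound 4 is 2 nM, with a range from 0.6 nM to 7 nM.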

Compound 4, half-maximal inhibitory concentration: 8 nM
Compound 4: the middle estimate sits 4.0-fold (0.60 log units) below what was measured; the whole stated range lies below it.
By their numbers in this assay, from the lowest: compound 2; then compound 1; then compounds 4 and 3 (each within the scatter of the next).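

In this assay, within the data shown here, the move at the aromatic carbon para to a large group gives a 10-fold higher number from compound 1 to compound 4 (1.00 log units; beyond the scatter), the first measured evidence that this position responds to the group it carries. The earlier step from compound 1 to compound 2 kept the chloro and could say nothing about this; here, chloro gives way to nitro, with three heavy atoms entering for one and two hydrogen-bond acceptors entering for none, and of these two groups at this place, chloro carries the lower number. No measurement on hand bears on what lies behind the rise, so the counted differences remain a description of the change and not an account of it.

The compounds shown leave open whether the rise is particular to nitro or follows from other replacements of chloro at this place, such as nitrile, methoxy, an amine or a carboxylic acid. They also leave open whether the amino group that lowered the number on the chloro compound would do the same alongside the nitro of compound 4.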